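The source may hold more compounds than are shown below. What is called first, only, known or untested is meant among the compounds shown, and "the series" means these compounds.

Measured in a functional assay on MDA-MB-231 cells (Homo sapiens) for antiproliferative activity, read by MTT assay, with a stated time of 48 h; a lower number here means a stronger inhibitor of growth, a higher number a weaker inhibitor of growth:
- compound 1 `CCCOC(=O)N1N=C(c2ccccc2)CC1c1cc(OC)c(OC)c(OC)c1`: 14400 nM
- compound 2 `CCCOC(=O)N1N=C(c2ccc(OC)cc2)CC1c1cc(OC)c(OC)c(OC)c1`: 20400 nM
- compound 3 `CCOC(=O)N1N=C(c2cccc(O)c2)CC1c1cc(OC)c(OC)c(OC)c1`: 4710 nM

In this assay, compound 3 at 4710 nM has the lowest of the three numbers, and compound 1 and compound 2 both lie beyond the scatter from it.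

The next structure is compound 4 `CCCOC(=O)N1N=C(c2cccc(O)c2)CC1c1cc(OC)c(OC)c(OC)c1`. It differs from compound 3 by methyl in place of hydrogen on a saturated chain carbon, two bonds along the chain from an oxygen next to a carbonyl group, which turns ethoxy to propoxy.

Among the compounds with values here, only one single-site step has been measured, a 1.4-fold higher number from compound 1 to compound 2 (0.15 log units; within the scatter). It is methoxy in place of hydrogen on an aromatic carbon, so it lies elsewhere in the molecule and does not test this change. Compound 1 at 14400 nM and compound 2 at 20400 nM carry the propoxy group, but each also differs from compound 3 in a second place, so their gaps cannot be credited to the chain alone. With no direct evidence, only a small upward step is expected, within the scatter. The expected step is a 1.3-fold higher number from compound 3 to compound 4 (0.11 log units; within the scatter).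

Compound 4 is estimated at 6000 nM, with an expected range of 2700 nM to 13500 nM.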

Compound 4, concentration for 50% growth inhibition: 10000 nM
For compound 4 the middle estimate is 1.7-fold (0.22 log units) below the measured one; measured number inside the range.
By their numbers in this assay, from the lowest: compound 3; then compounds 4, 1 and 2 (each within the scatter of the next, the first and the last beyond it).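

In this assay, within the data shown here, the change from ethoxy to propoxy gives the first direct reading at this chain position, with the 3-hydroxyphenyl group held fixed: a 2.1-fold higher number from compound 3 to compound 4 (0.33 log units; beyond the scatter), a modest step. With the propoxy group held fixed, 3-hydroxyphenyl in place of 4-methoxyphenyl gives a 2.0-fold lower number from compound 2 to compound 4 (0.31 log units; beyond the scatter), also modest, while a single added hydroxy gives only a 1.4-fold lower number from compound 1 to compound 4 (0.16 log units; within the scatter). So this one added methyl on the chain moves the number beyond the scatter, whereas the added hydroxy on the propoxy compounds does not.

Nothing available here offers a cause for these steps. On these data alone, it remains open whether a longer chain such as butoxy, a branched chain such as isopropoxy or an amine at the chain end would shift the number further, and whether hydroxy would give a larger step on an ethoxy compound.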